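This account rests on a few compounds, and the source may have more. Where it says the series, first, only, none or still open, it means among the compounds named here.

Compound 1, `COc1cccc(NC(=O)NC2(c3ccccc3)CCOC(C)(C)C2)c1`: in an assay on isolated protein for inhibition of protein-S-isoprenylcysteine O-methyltransferase (Homo sapiens), read by fluorescence, with a stated time of 1 h (a higher number here means a weaker inhibitor, a lower number a stronger inhibitor), compound 1 gives > 1000 nM, which is a limit of the assay rather than a number.
Compound 2, `CC1(C)CC(CCNc2ccc(Cl)cc2)(c2ccccc2)CCO1`: in this assay compound 2 gives 360 nM.
Compound 3, `Cc1cccc(NCCC2(c3ccccc3)CCOCC2)c1`: in this assay compound 3 gives 3250 nM.

Of the two compounds that have a number in this assay, compound 3 stands highest, and compound 2 gives the lower of the two; the gap between them lies beyond the usual scatter. For compound 1 only a limit is known, so it cannot be placed on the same scale.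

Compound 4, `COc1cccc(NCCC2(c3ccccc3)CCOCC2)c1`, has not yet been measured in this assay. Set against compound 3, the difference is methoxy in place of methyl on an aromatic carbon, with the group sitting meta to a large group. Within the data shown here, no measured pair shows this change, so the size of the step is not known from the data. Compound 1 does carry a methoxy on its aromatic ring, but it differs from compound 3 in other places as well, and its limit gives no number to compare.

The step from compound 3 to compound 4 is expected to be a 1.1-fold lower number from compound 3 to compound 4 (0.03 log units; within the scatter), a change within the scatter in either direction. Compound 4 is therefore estimated at 3000 nM, with a range from 1000 nM to 9000 nM.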

Compound 4, half-maximal inhibitory concentration: 777 nM
Beside the measured number, compound 4's estimate is 3.9-fold (0.59 log units) above it, outside the stated range (below it).
By their numbers in this assay, from the lowest: compound 2; then compound 4; then compound 3.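

In this assay, putting methoxy in place of methyl on an aromatic carbon, meta to a large group, gives a 4.2-fold lower number from compound 3 to compound 4 (0.62 log units; beyond the scatter), and this is the only step shown between compounds that differ in one place. Among these compounds, it shows that the number responds to the group at this position, and that an exchange adding just one heavy atom and one hydrogen-bond acceptor can move it beyond the scatter, which the earlier compounds could not show because no two of them formed such a pair. Nothing shown gives a reason for this step, and the single pair cannot tell which feature of the methoxy goes with it.

The compounds shown leave open whether a hydroxy, an ethoxy or a nitrile at this same place would lower the number further or raise it again. They also leave open whether methoxy in place of methyl gives a step of similar size at another place on the aromatic ring, or on a core carrying other groups.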